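Phenyl for cyclohexyl on the ether oxygen

The source may hold more compounds than are shown below. What is called first, only, known or untested is meant among the compounds shown, and "the series" means these compounds.

Measured in a functional assay on HT-29 cells (Homo sapiens) for inhibition, read by sulforhodamine B assay, with a stated time of 48 h; on this read-out lower numbers stand for stronger inhibition of growth and higher numbers for weaker inhibition of growth:
- compound 1 `c1cc(NC2=NCCO2)cc(OC2CCCC2)c1`: 52200 nM
- compound 2 `c1cc(NC2=NCCO2)cc(OC2CCCCC2)c1`: 4400 nM
- compound 3 `c1ccc(Oc2ccc(NC3=NCCO3)cc2)cc1`: 2000 nM

Compound 2 holds the middle place of the three numbers. Compound 2 gives 4400 nM and compound 3 gives 2000 nM. The number of compound 2 is the higher of these two, and the gap lies just beyond the scatter. Compound 1 gives 52200 nM, a far higher number than that of compound 2.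

The next compound to be measured is compound 4 `c1ccc(Oc2cccc(NC3=NCCO3)c2)cc1`. It differs from compound 2 as follows: phenyl in place of cyclohexyl on an oxygen on an aromatic ring. In words, this is phenyl in place of cyclohexyl on an oxygen on an aromatic ring.

Within the data shown here, only one measured step bears on this place, a 12-fold lower number from compound 1 to compound 2 (1.07 log units; beyond the scatter). That step is large, so the group on this oxygen can move the number strongly, and the range has to stay wide. It says nothing directly about phenyl, however. The closest evidence is compound 3, which also has phenyl on an oxygen on an aromatic ring and gives 2000 nM. A small move towards a lower number is therefore expected, not a large one. The estimated step is a 1.5-fold lower number from compound 2 to compound 4 (0.17 log units; within the scatter) in this assay. For compound 4 the expected value is 3000 nM, with an estimated range from 800 nM to 12000 nM.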

Compound 4, concentration for 50% growth inhibition: 5500 nM
Beside the measured number, compound 4's estimate is 1.8-fold (0.26 log units) below it; the range from low to high includes it.
By their numbers in this assay, from the lowest: compound 3; then compounds 2 and 4 (each within the scatter of the next); then compound 1.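

In this assay the swap from the saturated ring to the aromatic ring on this oxygen gives a 1.3-fold higher number from compound 2 to compound 4 (0.10 log units; within the scatter), so this read-out does not separate phenyl from cyclohexyl here, although the two groups differ in aromaticity and match in heavy-atom count. Against the five-membered group the picture is different: the change gives a 9.5-fold lower number from compound 1 to compound 4 (0.98 log units; beyond the scatter), which lies beyond the scatter, so among compounds 1, 2 and 4 the cyclopentyl ether of compound 1 stands alone, while the two six-membered rings sit together and no compound goes against this within the three. Nothing at hand explains why the five-membered group stands apart from the two six-membered rings, or why aromaticity makes no readable difference at this oxygen.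

Open, going by these compounds, is whether the tolerance for phenyl extends to a pyridyl ring, or to a phenyl ring carrying an amine, a carboxylic acid or a methoxy group. Also open, on these data alone, is how the number responds when a longer chain, such as benzyl or phenethyl, replaces the ring directly on this oxygen, and whether a smaller group such as methyl or a seven-membered carbon ring continues the gap between the ring sizes.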